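Methyl to Methoxy, Repeated on a Second Quinoline Amide Core

This account rests on a few compounds, and the source may have more. Where it says the series, first, only, none or still open, it means among the compounds named here.

Compound 2 `COc1cc2c(Oc3ccc(NC(=O)c4cc(-c5ccc(C)cc5)nc5ccccc45)cc3F)ccnc2cc1OCCCN1CCC(C)CC1` and compound 1 `COc1ccc(-c2cc(C(=O)Nc3ccc(Oc4ccnc5cc(OCCCN6CCC(C)CC6)c(OC)cc45)c(F)c3)c3ccccc3n2)cc1` share one core and differ in a single place: methoxy in place of methyl on an aromatic carbon. In a functional assay on NCI-H460 cells (Homo sapiens) for cytotoxicity, read by MTT assay, with a stated time of 72 h (a higher number here means a weaker inhibitor, a lower number a stronger inhibitor), compound 2 gives 880 nM, while compound 1 gives 110 nM, so that an 8.0-fold lower number from compound 2 to compound 1 (0.90 log units; beyond the scatter). Compound 3 `COc1cc2c(Oc3ccc(NC(=O)c4cc(-c5ccc(C)cc5)nc5ccc(F)cc45)cc3F)ccnc2cc1OCCCN1CCCCC1` is built on a second core; the difference between the two cores is not broken down here. In this assay compound 3 gives 260 nM, which stands between the values of compound 1 and compound 2.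

Compound 4 `COc1ccc(-c2cc(C(=O)Nc3ccc(Oc4ccnc5cc(OCCCN6CCCCC6)c(OC)cc45)c(F)c3)c3cc(F)ccc3n2)cc1` has not yet been measured. It differs from compound 3 in one place, (methoxy in place of methyl on an aromatic carbon), the same change that separates compound 2 from compound 1, made at the same kind of position. Within the data shown here, only that one earlier step is available, so the expectation rests on it alone and is tempered somewhat. In this assay the step from compound 3 to compound 4 is expected to be a 5.2-fold lower number from compound 3 to compound 4 (0.72 log units; beyond the scatter). Compound 4 is therefore estimated at about 50 nM in this assay, with a likely range from 20 nM to 150 nM.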

Compound 4, half-maximal inhibitory concentration: 240 nM
Compound 4: the middle estimate sits 4.8-fold (0.68 log units) below what was measured, outside the stated range (above it).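

In this assay, the exchange of 4-methylphenyl for 4-methoxyphenyl on the core of compound 3 gives a 1.1-fold lower number from compound 3 to compound 4 (0.03 log units; within the scatter), so on this core the two compounds cannot be told apart. The change therefore does not carry a fixed effect from one core to the other in this series, since the large step seen on the core of compound 2 does not recur on the second core: the same change on two cores in this assay, an 8.0-fold lower number (0.90 log units; beyond the scatter) from compound 2 to compound 1 and a 1.1-fold lower number (0.03 log units; within the scatter) from compound 3 to compound 4, 7.4-fold (0.87 log units) apart, beyond the scatter of two such steps The difference between the two cores is not broken down, so this comparison does not show which feature of the cores goes with the loss of the step, and one step on each core says nothing about how the change would read on a further core.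

The compounds shown leave open how an ethoxy group, a chlorine or an amine at the same place on the aromatic ring would read on either core. They also leave open whether the step would return on a core that carries only part of the difference between these two.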